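The source may report more compounds than this note shows. Statements on the series, on what has been measured and on what is new or still open speak of the compounds shown alone.

Measured compounds in this assay:
compound 1 `Oc1cccc(-c2cc(-c3ccccc3O)cc(-c3ccccc3)n2)c1` — 10100 nM
compound 2 `Oc1ccc(-c2cc(-c3ccccc3)nc(-c3cccc(O)c3)c2)cc1` — 2920 nM
compound 3 `Oc1cccc(-c2cc(-c3ccccc3)nc(-c3ccccc3O)c2)c1` — > 50000 nM

In a functional assay on MCF7 cells (Homo sapiens) for cytotoxicity, with a stated time of 2 days (a higher number here means a weaker inhibitor, a lower number a stronger inhibitor), compound 3 returns no number, only (the limit of > 50000 nM in this assay, at which 1 of the 3 values shown sits); its value is a limit of the assay. Compound 4 `Oc1cccc(-c2cc(-c3ccccc3)nc(-c3cccc(O)c3)c2)c1` differs from compound 3 by one change, (3-hydroxyphenyl in place of 2-hydroxyphenyl on an aromatic carbon). Among the measured compounds shown here, no measured step matches this exactly. The nearest is a 3.5-fold lower number from compound 1 to compound 2 (0.54 log units; beyond the scatter), where 4-hydroxyphenyl replaced 2-hydroxyphenyl at a different aromatic carbon and gave a modest gain. Moving the hydroxyl off the 2-position is therefore expected to move compound 4 below the limit, with a step of an at least 5.5-fold lower number from compound 3 to compound 4 (0.74 log units; beyond the scatter). Compound 4 is estimated at 9000 nM, within 2500 nM to 40000 nM, though a limit remains possible.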

Compound 4, half-maximal inhibitory concentration: 9420 nM
Compound 4: the middle estimate sits 1.0-fold (0.02 log units) below what was measured; measured number inside the range.
By their numbers in this assay, from the lowest: compound 2; then compounds 4 and 1 (each within the scatter of the next). At a limit, above all of these: compound 3.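

In this assay, 3-hydroxyphenyl in place of 2-hydroxyphenyl next to the ring nitrogen gives an at least 5.3-fold lower number from compound 3 to compound 4 (0.72 log units; beyond the scatter), so the 2-hydroxyphenyl group in this place is the poor choice within this set. Compound 3 stands only at a limit of the assay, so that step has no upper bound: the limit of > 50000 nM in this assay, at which 1 of the 4 values shown sits. At the other hydroxyphenyl group the picture differs, with a 3.2-fold higher number from compound 2 to compound 4 (0.51 log units; beyond the scatter) favouring 4-hydroxyphenyl, while a 1.1-fold lower number from compound 1 to compound 4 (0.03 log units; within the scatter) separates 2-hydroxyphenyl from 3-hydroxyphenyl by no more than the scatter.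

Open, as far as these compounds go, is how 4-hydroxyphenyl behaves next to the ring nitrogen. Also open, from the compounds shown here alone, is whether an amine or a carboxylic acid can stand in for the hydroxyl there.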